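Homologation of a Pyridinyl Amide in a Rat Edema Model

This account rests on a few compounds, and the source may have more. Where it says the series, first, only, none or still open, it means among the compounds named here.

Measured so far:
compound 1 `O=C(Nc1ccc([N+](=O)[O-])cc1)c1c(O)c2cccnc2n(-c2ccccc2)c1=O`: -25.8%
compound 2 `O=C(Nc1cccnc1)c1c(O)c2cccnc2n(-c2ccccc2)c1=O`: 30.8%

In a functional assay on the whole organism for inhibition, with Rattus norvegicus as the target, read by cytopathic effect and paw edema, at a dose of 100 mg/kg by the oral route (a higher number here means more inhibition at the dose given (going by the name of the read-out), a lower number less inhibition), compound 2 stands highest of the two numbers; the step of a number 56.6 percentage points higher from compound 1 to compound 2 (beyond the scatter) separates it from compound 1. Compound 3 `O=C(NCc1cccnc1)c1c(O)c2cccnc2n(-c2ccccc2)c1=O` differs from compound 2 by (pyridin-3-yl)methyl in place of pyridin-3-yl on an amide-type nitrogen. For the measured compounds named here, no measured step covers this kind of change, since the one step known concerns a different exchange on the same amide-type nitrogen, so no firm direction can be drawn from it. The author therefore expects compound 3 to stay near compound 2, with a step of a number 8.8 percentage points lower from compound 2 to compound 3 (within the scatter) that need not exceed the scatter. The estimate for compound 3 is 22%, ranging from -12% to 50%.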

Compound 3, a percentage reported as inhibition, in the whole organism at one dose (the size of the read-out at that dose, not a potency): 14.7%
Beside the measured number, compound 3's estimate is 7.3 percentage points above it; low and high end bracket the measured number.
By their numbers in this assay, from the lowest: compound 1; then compound 3; then compound 2.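

On the amide-type nitrogen in this assay, (pyridin-3-yl)methyl in place of pyridin-3-yl gives a number 16.1 percentage points lower from compound 2 to compound 3 (beyond the scatter) and a modest loss, so this position responds even to a change of a single added carbon. The same group in place of 4-nitrophenyl gives a number 40.5 percentage points higher from compound 1 to compound 3 (beyond the scatter) and remains a large gain, so the pyridine-bearing amides stay clearly apart from compound 1. As far as these compounds go, whether a longer chain such as 2-(pyridin-3-yl)ethyl would lower the number further, or a benzyl group would behave alike, stays open. No measurement shown bears on what lies behind these steps.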